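The compounds below may be only part of what the source reports. "The series", "measured", "known", "first", "only" and "open" are said of these compounds alone.

The series comprises three measured compounds and one that remains to be tested. Compound 1 `COc1ccc(CCCc2ccc(OC)c(OC)c2)c(O)c1`, compound 2 `COc1ccc(CCCc2ccc(OC)cc2OC)c(O)c1` and compound 3 `COc1ccc(CCC(=O)c2ccc(OC)c(OC)c2)cc1O` share a diaryl core with a three-carbon link, and all were examined in an ADME assay on RAW264.7 cells (Mus musculus) for cytotoxicity, read by MTT assay, with a stated time of 24 h, tested at 10 ug/mL; on this read-out higher numbers stand for a weaker effect at the one concentration tested and lower numbers for a stronger effect. Compound 1 gives 44.5%. Compound 2 gives 25.8%, the lowest of the three numbers and thus the strongest effect seen here; compound 1 stands closest to it, beyond the scatter, while compound 3 stands furthest away, also beyond the scatter. Compound 3 gives 83.9%.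

The unmeasured compound 4 `COc1ccc(CCCc2ccc(OC)cc2O)cc1` departs from compound 2 by a single change: hydrogen in place of methoxy on an aromatic carbon. Going by the values given here, no pair of measured compounds that differ in just one place is available, so the size of this step cannot be read from the data. The expected step is a number 12.2 percentage points higher from compound 2 to compound 4 (beyond the scatter). Compound 4 is therefore estimated to give 38%, with a range of 18% to 65%.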

Compound 4, a percentage reported as activity, at one concentration (the size of the read-out at that concentration, not a potency): 73.8%
Compound 4: middle estimate off by 35.8 percentage points, on the low side; the measured number lies above the stated range.
By their numbers in this assay, from the lowest: compound 2; then compound 1; then compound 4; then compound 3.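

In this assay the number rises a number 48 percentage points higher from compound 2 to compound 4 (beyond the scatter) and a number 29.3 percentage points higher from compound 1 to compound 4 (beyond the scatter) when hydrogen takes the place of methoxy on an aromatic carbon, giving the series its first readable steps. Both steps lie beyond the scatter and point the same way, so in these two pairs the compound that keeps the methoxy group shows the stronger effect at the one concentration tested. Nothing at hand explains this rise.

Going by these compounds, whether fluorine or an ethoxy group at this place would hold the number close to that of compound 2 remains open. Also open, on these data alone, is whether the same exchange would move the number in the same direction on the core of compound 3, which carries a carbonyl in its link.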